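The compounds below may be only part of what the source reports. "The series", "measured", "known", "first", "only" and "open" are said of these compounds alone.

Among the measured compounds shown here, in a functional assay on HCC827 cells (Homo sapiens) for inhibition, read by fluorescence, with a stated time of 72 h (on this read-out higher numbers stand for weaker inhibition of growth and lower numbers for stronger inhibition of growth), compound 1 (`CCCCCCn1cnc2c(Nc3cccc(Cl)c3)nc(N[C@H]3CC[C@H](N)CC3)nc21`) gives 10200 nM and compound 2 (`CC(C)CCn1cnc2c(Nc3cccc(Cl)c3)nc(N[C@H]3CC[C@H](N)CC3)nc21`) gives 10300 nM, so compound 2 stands level with its only neighbour. Compound 3 (`CC(C)=CCC/C(C)=C/Cn1cnc2c(Nc3cccc(Cl)c3)nc(N[C@H]3CC[C@H](N)CC3)nc21`) alters the chain of compound 2: 2,6-dimethylhepta-1,5-dien-1-yl in place of isobutyl on a saturated chain carbon bound to an aromatic nitrogen. For the measured compounds named here, the one measured step that bears on this is a 1.0-fold higher number from compound 1 to compound 2 (0.00 log units; within the scatter), and it shows no movement. The 2,6-dimethylhepta-1,5-dien-1-yl group goes well beyond that small swap, so the evidence is thin, and only a modest shift toward stronger inhibition of growth is expected. The expected change is a 1.5-fold lower number from compound 2 to compound 3 (0.17 log units; within the scatter). Compound 3 is estimated at 7000 nM, within an expected range of 2000 nM to 16000 nM.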

Compound 3, concentration for 50% growth inhibition: 18200 nM
Compound 3: the middle estimate sits 2.6-fold (0.41 log units) below what was measured; the whole stated range lies below it.
By their numbers in this assay, from the lowest: compounds 1, 2 and 3 (each within the scatter of the next).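

In this assay, 2,6-dimethylhepta-1,5-dien-1-yl in place of isobutyl gives a 1.8-fold higher number from compound 2 to compound 3 (0.25 log units; within the scatter) and in place of pentyl gives a 1.8-fold higher number from compound 1 to compound 3 (0.25 log units; within the scatter) at this place on a saturated chain carbon bound to an aromatic nitrogen. So even a chain of 9 heavy atoms with 2 double bonds reads level with the two shorter chains. No measurement shown explains this result. As far as these compounds go, all three chains contain only carbon and hydrogen, so it remains open whether a chain ending in an amine or a carboxylic acid would move the number beyond the scatter.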